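The compounds below may be only part of what the source reports. "The series", "measured", "known", "first", "only" and "open" are said of these compounds alone.

Measured in a functional assay on SW1573 cells (Homo sapiens) for inhibition, read by sulforhodamine B assay, with a stated time of 48 h; a higher number here means a weaker inhibitor of growth, a lower number a stronger inhibitor of growth:

compound 1 `COC(=O)[C@@]1(C)CCC=C2[C@@H]1CC[C@@H](C)[C@]2(C)Cc1c(C)[nH]c2ccc(Br)cc12` — 14000 nM
compound 2 `COC(=O)[C@@]1(C)CCC=C2[C@@H]1CC[C@@H](C)[C@]2(C)Cc1c(C)[nH]c2ccc(OC)cc12` — 15000 nM
compound 3 `COC(=O)[C@@]1(C)CC[C@@H]2C3=C1CC[C@@H](C)[C@]3(C)Cc1c2[nH]c2ccc(Br)cc12` — 12000 nM

Compound 1 and compound 2 share a core and differ by methoxy in place of bromo on an aromatic carbon; in this assay this gave a 1.1-fold higher number from compound 1 to compound 2 (0.03 log units; within the scatter), so the two values sit together without any ordering between them. Compound 3 carries a different core; the difference between the two cores is not broken down here. Among the three, compound 3 has the lowest number, but its distance to compound 1 and to compound 2 is within the scatter, so no compound is called the stronger growth inhibitor.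

Compound 4 `COC(=O)[C@@]1(C)CC[C@@H]2C3=C1CC[C@@H](C)[C@]3(C)Cc1c2[nH]c2ccc(OC)cc12` is not yet measured. It differs from compound 3 by methoxy in place of bromo on an aromatic carbon. This is the same kind of change as that from compound 1 to compound 2, though the surroundings differ as stated: in compound 4 the aromatic carbon is part of a fused or bridged system of five rings, where in compound 2 it is part of a system of two rings. Because a 1.1-fold higher number from compound 1 to compound 2 (0.03 log units; within the scatter) lay within the scatter, the step for compound 4 is expected to be a 1.1-fold higher number from compound 3 to compound 4 (0.03 log units; within the scatter), small in the same way. Compound 4 is therefore estimated at 13000 nM in this assay, within 7000 nM to 25000 nM.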

Compound 4, concentration for 50% growth inhibition: 5900 nM
The estimate for compound 4 lay 2.2-fold (0.34 log units) above the measured number; measured number outside the range, below it.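

In this assay, methoxy in place of bromo on an aromatic carbon gives a 2.0-fold lower number from compound 3 to compound 4 (0.31 log units; beyond the scatter), a modest step on the core of compound 3. Set beside the same change on the core of compound 1, this step gives no ground for calling the two cores different in their response: the same change on two cores in this assay, a 1.1-fold higher number (0.03 log units; within the scatter) from compound 1 to compound 2 and a 2.0-fold lower number (0.31 log units; beyond the scatter) from compound 3 to compound 4, 2.2-fold (0.34 log units) apart, within the scatter of two such steps. This does not show that the change carries over unaltered, nor that its size depends on the core: each core offers a single pair, and the step lies beyond the scatter on one core and within it on the other.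

Still open, as far as these compounds go, is whether other groups on this aromatic carbon, such as an amine, a carboxylic acid or a longer alkoxy chain, would shift the number in the same way on both cores. Also open, from the compounds shown here alone, is how the number would respond on either core if the methyl ester gave way to a carboxylic acid or an amide.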